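A Methyl for a Chloro in Bombesin Receptor Agonists

A few compounds are considered here, and "the series" means these few. Any claim that something is new, unique, unknown or untested is made for them only; others in the source may bear on it.

Measured compounds:
compound 1, `CCCCc1cnc(C(CCC)Cc2ccc(-c3ccccc3C(=O)O)cc2)[nH]1`: 1180 nM
compound 2, `O=C(O)c1ccccc1-c1ccc(CCc2ncc(Cc3ccc(Cl)cc3)[nH]2)cc1`: 2290 nM
compound 3, `CCCCc1cnc(/C=C/c2ccc(-c3ccccc3C(=O)O)cc2)[nH]1`: 4380 nM

Of the compounds shown here, three built on a shared core have been tested in an in vitro functional assay on cells for agonist activity at Bombesin receptor subtype-3 (Homo sapiens), read by luminescence and calcium flux; a higher number here means that more compound is needed for the effect, a lower number that less compound is needed. In this assay compound 1 gives 1180 nM, compound 2 gives 2290 nM, and compound 3 gives 4380 nM. Compound 2 holds the second highest of the three numbers, yet its gap to compound 3, the nearest value, and its gap to compound 1, the furthest value, both fall within the usual scatter of this assay, so the three cannot be put in a reliable order.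

Compound 4, `Cc1ccc(Cc2cnc(CCc3ccc(-c4ccccc4C(=O)O)cc3)[nH]2)cc1`, has not yet been measured. Compared with compound 2 it shows (methyl in place of chloro on an aromatic carbon). Going by the values given here, no measured pair in this set carries that same change, so the size of its effect cannot be read from the data.

The expected step is a 1.1-fold higher number from compound 2 to compound 4 (0.04 log units; within the scatter), which is no more than the scatter and in no particular direction. Compound 4 is therefore expected to give about 2500 nM, within a range from 900 nM to 7000 nM.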

Compound 4, half-maximal effective concentration: 2660 nM
Compound 4: the middle estimate sits 1.1-fold (0.03 log units) below what was measured; the range from low to high includes it.
By their numbers in this assay, from the lowest: compounds 1, 2, 4 and 3 (each within the scatter of the next, the first and the last beyond it).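

In this assay the swap of 4-chlorobenzyl for 4-methylbenzyl amounts to a 1.2-fold higher number from compound 2 to compound 4 (0.07 log units; within the scatter) and so, at this place on the six-membered aromatic ring, para to a large group, chloro and methyl cannot be told apart by their numbers. The earlier compounds shown here could not show this, since none of them differ in one place, whereas this pair isolates a single change: one heavy atom exchanged for one heavy atom, with no hydrogen-bond donor or acceptor on either side. Nothing available explains why the two groups read alike.

The compounds shown leave open whether a hydroxyl, an amine, a carboxylic acid or a longer chain at this same place would also stay within the scatter of compound 2 or would move the number beyond it. They also leave open whether methyl in place of chloro would read the same way at another carbon of this ring, since this one pair speaks for a single place only.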